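The source may report more compounds than this note shows. Statements on the series, on what has been measured and on what is new or still open speak of the compounds shown alone.

Measured so far:
compound 1 `O=C(CCCCC1CCSS1)NCc1cn(CCCOc2ccc3cc(-c4ccc(Cl)cc4)c(=O)oc3c2)nn1`: 60.6%
compound 2 `CCOC(=O)c1cc2ccc(OCCCCCn3cc(CNC(=O)CCCCC4CCSS4)nn3)cc2oc1=O`: 36.4%

In a functional assay on PC-12 cells (Rattus norvegicus) for cytotoxicity, read by MTT assay, with stated times of 3 h and 2 h, tested at 5 uM (on this read-out higher numbers stand for a stronger effect at the one concentration tested and lower numbers for a weaker effect), compound 2 gives 36.4%, the lowest of the two numbers. Compound 1 gives 60.6%, higher by an amount beyond the scatter. Compound 3 `O=C(CCCCC1CCSS1)NCc1cn(CCCCCOc2ccc3cc(-c4ccc(Br)cc4)c(=O)oc3c2)nn1` differs from compound 2 by 4-bromophenyl in place of ethoxycarbonyl on an aromatic carbon. Among the measured compounds shown here, no measured pair shows this change on its own, so no step size is known for it. Because compound 1 gives 60.6%, the step is expected to be upward and beyond the scatter, a number 18.6 percentage points higher from compound 2 to compound 3 (beyond the scatter). Compound 3 is estimated at 55%, in the range 40% to 70%.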

Compound 3, a percentage reported as activity, at one concentration (the size of the read-out at that concentration, not a potency): 45.7%
Beside the measured number, compound 3's estimate is 9.3 percentage points above it; the measured number falls inside the stated range.
By their numbers in this assay, from the lowest: compounds 2 and 3 (each within the scatter of the next); then compound 1.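

In this assay, 4-bromophenyl in place of ethoxycarbonyl on this aromatic carbon, two atoms from the ring oxygen, gives a number 9.3 percentage points higher from compound 2 to compound 3 (within the scatter) and does not separate the two compounds. The position therefore accepts a six-membered aromatic ring of carbon only, with no hydrogen-bond acceptors in the group, without a read-out change beyond the scatter. No measurement at hand gives a reason for this result.

On these data alone, whether an amine or a carboxylic acid on this aromatic carbon would separate from these two groups in this assay remains open. So does the outcome with a longer chain in the linker.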